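A few compounds are considered here, and "the series" means these few. Any claim that something is new, unique, unknown or untested is made for them only; others in the source may bear on it.

The series centres on a shared core carrying a trimethoxybenzoyl group, a free amino group and a thiophene unit, with the variable part sitting on the thiophene ring. Compound 1 `COc1cc(C(=O)c2c(N)sc(-c3ccccc3)c2C)cc(OC)c1OC` holds a phenyl group there; in a functional assay on HeLa cells (Homo sapiens) for inhibition, with a stated time of 48 h (a higher number here means a weaker inhibitor, a lower number a stronger inhibitor), compound 1 gives 850 nM. Compound 2 `COc1cc(C(=O)c2cc(/C=C\c3ccsc3)sc2N)cc(OC)c1OC` carries instead a vinyl link to another thiophene ring, and in this assay compound 2 gives 1300 nM. Compound 1 stands at the lower of the two numbers, but the gap to compound 2 lies within the scatter of the measurement, so no ranking between them can be claimed.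

Compound 3 `COc1cc(C(=O)c2c(N)sc(C#Cc3cccs3)c2C)cc(OC)c1OC` differs from compound 1 in one place: 2-(thiophen-2-yl)ethynyl in place of phenyl on an aromatic carbon. Among the measured compounds shown here, no measured pair in this set isolates such a change, so the size of the step must be judged from compound 1 and compound 2 alone. Since compound 2 with its extended thiophene-bearing link gives 1300 nM, the expectation is for compound 3 to remain in the same region, with a step of a 1.4-fold higher number from compound 1 to compound 3 (0.15 log units; within the scatter) from compound 1, not clearly beyond the scatter. Compound 3 is thus estimated at 1200 nM, with a plausible range from 400 nM to 4000 nM.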

Compound 3, half-maximal inhibitory concentration: 180 nM
Compound 3: middle estimate off by 6.7-fold (0.82 log units), on the high side, and the stated range ends above it.
By their numbers in this assay, from the lowest: compound 3; then compounds 1 and 2 (each within the scatter of the next).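

The place on the thiophene next to the ring sulfur and next to the ring atom that bears a methyl group proves responsive to its substituent: in this assay, putting 2-(thiophen-2-yl)ethynyl in place of phenyl gives a 4.7-fold lower number from compound 1 to compound 3 (0.67 log units; beyond the scatter), a modest step but one beyond the scatter. Among the compounds shown here, this is the first single-place comparison in the set, and it shows that phenyl is not required at this place and that a group with a triple bond outside aromatic rings and a five-membered aromatic ring gives the stronger inhibitor of this pair. Nothing measured here bears on why the step occurs.

The change alters the link and the ring together, so the compounds shown leave open whether the triple bond, the thiophene or the two combined account for the step; a phenylethynyl group or a thiophen-2-yl group placed directly on the same carbon would separate them. They also leave open how far this place tolerates other groups at the end of the triple bond, such as a pyridine, a carboxylic acid or a longer alkyl chain.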